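This account rests on a few compounds, and the source may have more. Where it says the series, first, only, none or still open, it means among the compounds named here.

Three compounds have so far been measured in a functional assay on A549 cells (Homo sapiens) for antiproliferative activity, read by sulforhodamine B assay, with a stated time of 48 h; on this read-out lower numbers stand for stronger inhibition and higher numbers for weaker inhibition:

Compound 1, `COc1cc(C=C(C(=O)/C=C/c2cccc(OC)c2OC)C(=O)/C=C/c2cccc(OC)c2OC)ccc1O`, gives 130 nM.
Compound 2, `COc1cccc(/C=C/C(=O)C(=Cc2ccc(O)c(F)c2)C(=O)/C=C/c2cccc(OC)c2OC)c1OC`, gives 200 nM.
Compound 3, `COc1ccc(/C=C/C(=O)C(=Cc2ccc(O)c(OC)c2)C(=O)/C=C/c2ccc(OC)cc2OC)c(OC)c1`, gives 590 nM.

Compound 1 and compound 2 share a core and differ in one place, (fluoro in place of methoxy on an aromatic carbon). This change produced a 1.5-fold higher number from compound 1 to compound 2 (0.19 log units; within the scatter), so on this read-out the two are not told apart. Compound 3 is built from the same atoms as compound 1, joined differently; the difference between the two cores is not broken down here. Compound 3 gives the highest of the three numbers, and its gap to compound 2 as well as to compound 1 lies beyond the usual scatter, so on the core of compound 3 the inhibition is weaker than on the core shared by compound 1 and compound 2.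

Compound 4, `COc1ccc(/C=C/C(=O)C(=Cc2ccc(O)c(F)c2)C(=O)/C=C/c2ccc(OC)cc2OC)c(OC)c1`, has not yet been measured. It stands to compound 3 as compound 2 stands to compound 1: the change is fluoro in place of methoxy on an aromatic carbon, and the surroundings of the place are described in the same words in both pairs, so this is the same change made on a different core. Because the earlier instance gave a 1.5-fold higher number from compound 1 to compound 2 (0.19 log units; within the scatter), the step from compound 3 to compound 4 is expected to be of similar small size, a 1.4-fold higher number from compound 3 to compound 4 (0.16 log units; within the scatter), with the core of compound 3 setting the level. Compound 4 is therefore estimated at 850 nM in this assay. For compound 4 the expected range runs from 400 nM to 1800 nM.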

Compound 4, half-maximal inhibitory concentration: 2070 nM
The estimate for compound 4 lay 2.4-fold (0.39 log units) below the measured number; measured number outside the range, above it.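

In this assay, exchanging 4-hydroxy-3-methoxyphenyl for 3-fluoro-4-hydroxyphenyl on the core of compound 3 gave a 3.5-fold higher number from compound 3 to compound 4 (0.55 log units; beyond the scatter), so on this core the fluoro compound is the weaker of the pair, by a step larger than the usual scatter. Set beside the same exchange on the core of compound 1, this larger step still cannot be told apart from the earlier one: the same change on two cores in this assay, a 1.5-fold higher number (0.19 log units; within the scatter) from compound 1 to compound 2 and a 3.5-fold higher number (0.55 log units; beyond the scatter) from compound 3 to compound 4, 2.3-fold (0.36 log units) apart, within the scatter of two such steps. The two pairs are therefore compatible with the change carrying over from one core to the other as a step of like size, but they do not show that the core alters the step, and two pairs cannot show that it would hold on any further core in the series.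

The compounds shown leave open how other groups would fare on this aromatic carbon, ortho to a hydroxy group, such as chloro, a nitrile, an amine or a longer alkoxy chain in place of the methoxy. They also leave open whether the step would persist if the neighbouring hydroxy group gave way to a carboxylic acid or an amine.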